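Swapping the Alkyne Aryl Group in an mGlu5 Modulator Series

A few compounds are considered here, and "the series" means these few. Any claim that something is new, unique, unknown or untested is made for them only; others in the source may bear on it.

Measured compounds:
- compound 1, `C[C@@H](NC(=O)c1ccc(C#Cc2cccc(F)c2)cn1)C(C)(C)C`: 66%
- compound 2, `O=C(NCC1CCC1)c1ccc(C#Cc2cccc(F)c2)cn1`: 68.1%
- compound 3, `CC1(CCNC(=O)c2ccc(C#Cc3cccc(F)c3)cn2)COC1`: 65.7%

In a functional assay on HEK293 cells for positive allosteric modulation of metabotropic glutamate receptor 5 (Rattus norvegicus), read by fluorescence and calcium flux (on this read-out lower numbers stand for smaller maximal responses and higher numbers for larger maximal responses), compound 1 gives 66%. On these three numbers compound 1 stands second highest, yet all three lie within the scatter of one another: a number 2.1 percentage points higher from compound 1 to compound 2 (within the scatter) and a number 0.3 percentage points lower from compound 1 to compound 3 (within the scatter), while a number 2.4 percentage points lower from compound 2 to compound 3 (within the scatter). None of these steps therefore shows a real change in the largest response.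

Compound 4, `C[C@@H](NC(=O)c1ccc(C#Cc2ccccn2)cn1)C(C)(C)C`, has not yet been measured. It differs from compound 1 in one place: pyridin-2-yl in place of 3-fluorophenyl on a triple-bonded carbon. Within the data shown here, every step measured so far alters the group on the amide-type nitrogen, and none touches the group on the triple-bonded carbon, so no measured step bears directly on this change. Among the measured compounds shown here, the only guidance is that the three measured compounds sit close together in this assay. The largest response of compound 4 is therefore expected to stay near that of compound 1, with a number 2 percentage points lower from compound 1 to compound 4 (within the scatter) as the expected step and a wider range to reflect the absence of a matching comparison. The estimate for compound 4 is 64%, between 45% and 82%.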

Compound 4, largest response reached (reported as efficacy), in percent of the reference or control that the assay uses: 63%
Beside the measured number, compound 4's estimate is 1 percentage points above it; the measured number falls inside the stated range.
By their numbers in this assay, from the lowest: compounds 4, 3, 1 and 2 (each within the scatter of the next).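

Among these compounds, compound 4 is the first compound here that changes the group on the triple-bonded carbon rather than the group on the amide-type nitrogen, and the swap gives a number 3 percentage points lower from compound 1 to compound 4 (within the scatter) in this assay on the largest response. Pyridin-2-yl, which brings a ring nitrogen and one hydrogen-bond acceptor, can therefore take the place of 3-fluorophenyl at this position without a real change in this read-out, at least in this single pair. Nothing at hand explains why these two groups give such similar responses.

As far as these compounds go, it remains open whether the same swap would hold with the cyclobutylmethyl group of compound 2 or the 2-(3-methyloxetan-3-yl)ethyl group of compound 3 on the amide-type nitrogen. From the compounds shown here alone, how an unsubstituted phenyl or a pyridin-3-yl would compare on the triple-bonded carbon also remains open.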